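Replacing Allyl with 4-Fluorobenzyl on a Quinoline Ether

The compounds below may be only part of what the source reports. "The series", "measured", "known", "first", "only" and "open" are said of these compounds alone.

Measured compounds in a functional assay on BGC-823 cells (Homo sapiens) for cytotoxicity, read by MTT assay, with a stated time of 48 h; on this read-out higher numbers stand for weaker inhibition and lower numbers for stronger inhibition:
compound 1, `CCCCCCOc1ccc2c(Cl)ccnc2c1`, 2380 nM
compound 2, `C=CCOc1ccc2c(NCCCN(C)C)ccnc2c1`, 6680 nM
compound 3, `CCCCCCOc1ccc2c(NCCN(C)C)ccnc2c1`, 1090 nM

Compound 2 stands at the weak end of the three: in this assay compound 2 gives the highest number, with compound 1 next and compound 3 furthest, both beyond the scatter.

The new compound 4, `CN(C)CCCNc1ccnc2cc(OCc3ccc(F)cc3)ccc12`, keeps the side chain of compound 2 and changes only the group on the ether oxygen: 4-fluorophenyl in place of vinyl on a saturated chain carbon bound to an oxygen on an aromatic ring.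

For the measured compounds named here, only one measured step joins two compounds that differ in a single place, a 2.2-fold lower number from compound 1 to compound 3 (0.34 log units; beyond the scatter), and it concerns the group on the aromatic carbon, not the ether. No measured pair isolates a change at the ether position, so nothing shown speaks directly to the size or direction of this step. Compounds 1 and 3, which carry a longer chain on the oxygen than compound 2, both give lower numbers, but each also differs from compound 2 elsewhere, so that comparison is only suggestive.

Taken together, a modest decrease in number is expected, a 2.7-fold lower number from compound 2 to compound 4 (0.43 log units; beyond the scatter), with wide uncertainty. For compound 4 the estimate in this assay is 2500 nM, within 800 nM to 8000 nM.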

Compound 4, half-maximal inhibitory concentration: 490 nM
Compound 4: middle estimate off by 5.1-fold (0.71 log units), on the high side; the whole stated range lies above it.
By their numbers in this assay, from the lowest: compound 4; then compound 3; then compound 1; then compound 2.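

In this assay, for the compounds shown here, the change from allyl to 4-fluorobenzyl gives a 14-fold lower number from compound 2 to compound 4 (1.13 log units; beyond the scatter) and provides the first pair that isolates the group on the ether oxygen. Going by these compounds alone, with the side chain and the core held fixed, this single swap moves the number much further than the only other single-place step, which is a 2.2-fold lower number from compound 1 to compound 3 (0.34 log units; beyond the scatter) and concerns the group on the aromatic carbon. The position also accepts a much larger group, with 7 heavy atoms and a six-membered aromatic ring entering where the 2 heavy atoms of vinyl leave, and the number falls rather than rises.

The swap brings in the aromatic ring and the fluorine together, so the compounds shown cannot say which of the two matters: a plain benzyl group would separate them, and a hexyl group on this same side chain would test whether a ring is needed at all. No evidence is available to explain why the number falls this far.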